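Flipping the Ring Configuration of Compound 1

A few compounds are considered here, and "the series" means these few. Any claim that something is new, unique, unknown or untested is made for them only; others in the source may bear on it.

Compound 1 `C[C@]1(O)C[C@](c2cccc(OC(F)(F)F)c2)([C@H](O)c2ccccn2)C1` was tested in an assay on HEK293 cells for antagonist activity at transient receptor potential cation channel subfamily V member 3 (Homo sapiens), read by FLIPR and calcium flux (a higher number here means a weaker inhibitor, a lower number a stronger inhibitor), where compound 1 gives 1310 nM. Within the data shown here, that is the higher of the two numbers measured so far. Among the measured compounds shown here, the only other measured compound is compound 2 `O[C@H](c1ccccn1)[C@]1(c2cccc(OC(F)(F)F)c2)C[C@H](O)C1`, which in this assay gives 40 nM; the change from compound 1 to compound 2 is a hydrogen in place of methyl on a saturated ring carbon, and it brings a 33-fold lower number from compound 1 to compound 2 (1.52 log units; beyond the scatter).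

Compound 3 `C[C@]1(O)C[C@@](c2cccc(OC(F)(F)F)c2)([C@H](O)c2ccccn2)C1` has not yet been measured. Compared with compound 1, (the two compounds have the same atoms and bonds and differ only in configuration as drawn: 2 of 3 stereo elements differ; a stereocentre at a saturated ring carbon is drawn S in compound 1 and R in compound 3; a stereocentre at a saturated ring carbon is drawn r in compound 1 and s in compound 3). For the measured compounds named here, no measured step consists of a change of configuration alone, so the step from compound 1 to compound 2 bears on it only indirectly: it shows that the ring carbon carrying the methyl is a place where the numbers move a great deal, which makes a sizeable shift in either direction plausible for compound 3, though its direction cannot be read from the data. With the methyl retained, the expected number for compound 3 in this assay is estimated at 450 nM, with a range from 80 nM to 2500 nM, an expected step of a 2.9-fold lower number from compound 1 to compound 3 (0.46 log units; beyond the scatter).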

Compound 3, antagonist equilibrium constant: 280 nM
Compound 3: the middle estimate sits 1.6-fold (0.21 log units) above what was measured; measured number inside the range.
By their numbers in this assay, from the lowest: compound 2; then compound 3; then compound 1.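

In this assay, the arrangement of the groups in space matters on its own: the step is a 4.7-fold lower number from compound 1 to compound 3 (0.67 log units; beyond the scatter), although nothing leaves and nothing enters. This step can be put down to configuration alone because of one plain fact about the pair: the fact that compounds 1 and 3 differ only in the configuration as drawn. The earlier step, a 33-fold lower number from compound 1 to compound 2 (1.52 log units; beyond the scatter), showed only what happens when hydrogen replaces methyl on a saturated ring carbon, whereas compound 1 and compound 3 both keep the methyl, so the presence of the methyl does not by itself fix the number.

Two stereo elements differ together between compound 1 and compound 3, so the compounds shown leave open how much of the step belongs to each, and whether the hydrogen-for-methyl change would have a similar effect in the configuration of compound 3. They also leave open how a different group on the same ring carbon, such as an amine or an ethyl chain, would behave in either configuration.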